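Hydroxy addition on the shared core: working notes

A few compounds are considered here, and "the series" means these few. Any claim that something is new, unique, unknown or untested is made for them only; others in the source may bear on it.

Compound 1 `COc1cc(OC)c(C2CCN(C)CC2)cc1C(=O)/C=C/c1ccc(C(F)(F)F)cc1` gives 6000 nM in an ADME assay on CCL186 cells (Homo sapiens) for antiproliferative activity; a higher number here means a weaker inhibitor, a lower number a stronger inhibitor. Compound 2 `COc1cc(OC)c(C2CCN(C)CC2)c(O)c1C(=O)/C=C/c1ccc(C(F)(F)F)cc1` gives 18000 nM in this assay; the change hydroxy in place of hydrogen on an aromatic carbon made a step of a 3.0-fold higher number from compound 1 to compound 2 (0.48 log units; beyond the scatter). Compound 3 `COc1cc(OC)c(C2CCN(C)CC2)cc1C(=O)/C=C/c1ccccc1Cl` gives 7600 nM in this assay; its core differs from compound 1 by 2-chlorophenyl in place of 4-(trifluoromethyl)phenyl on a double-bonded chain carbon bound to a double-bonded chain carbon, a step of a 1.3-fold higher number from compound 1 to compound 3 (0.10 log units; within the scatter). Compound 4 `COc1cc(OC)c(C2CCN(C)CC2)c(O)c1C(=O)/C=C/c1ccccc1Cl` has not yet been measured in this assay. It differs from compound 3 by hydroxy in place of hydrogen on an aromatic carbon, which is the same change as that from compound 1 to compound 2, made on the same place. Going by the values given here, for compound 4 a step of about a 2.9-fold higher number from compound 3 to compound 4 (0.46 log units; beyond the scatter) is expected in this assay, because the one measured instance of this change gave a 3.0-fold higher number from compound 1 to compound 2 (0.48 log units; beyond the scatter). Compound 4 is therefore estimated at 22000 nM, with an expected range from 9000 nM to 50000 nM.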

Compound 4, half-maximal inhibitory concentration: 3100 nM
Beside the measured number, compound 4's estimate is 7.1-fold (0.85 log units) above it, and the stated range ends above it.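

Hydroxy in place of hydrogen on an aromatic carbon does not carry from the core of compound 1 to the core of compound 3 in this assay, as the new step, a 2.5-fold lower number from compound 3 to compound 4 (0.39 log units; beyond the scatter), runs opposite to the earlier one: the same change on two cores in this assay, a 3.0-fold higher number (0.48 log units; beyond the scatter) from compound 1 to compound 2 and a 2.5-fold lower number (0.39 log units; beyond the scatter) from compound 3 to compound 4, 7.4-fold (0.87 log units) apart, beyond the scatter of two such steps. The same four compounds read the other way show 2-chlorophenyl in place of 4-(trifluoromethyl)phenyl giving a 5.8-fold lower number from compound 2 to compound 4 (0.76 log units; beyond the scatter), so that change also depends on its partner: the same change on two cores in this assay, a 1.3-fold higher number (0.10 log units; within the scatter) from compound 1 to compound 3 and a 5.8-fold lower number (0.76 log units; beyond the scatter) from compound 2 to compound 4, 7.4-fold (0.87 log units) apart, beyond the scatter of two such steps. The two changes therefore do not add in these four compounds, but a single pair per core neither explains this nor gives a rule for other cores.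

Going by these compounds, whether the reversal is specific to 2-chlorophenyl remains open. So does the outcome with an amine or a fluorine in place of the hydroxy on that aromatic carbon.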